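The source may hold more compounds than are shown below. What is called first, only, known or untested is meant among the compounds shown, and "the series" means these compounds.

Measured compounds:
Compound 1 `CCc1ccc(OCC(=O)N(CC)Cc2cccs2)cc1`: 67 nM
Compound 2 `Cc1ccc(OCC(=O)N(Cc2cccs2)C2CCCCC2)cc1`: 40000 nM

In an assay on HEK293 cells for agonist activity at transient receptor potential cation channel subfamily M member 8 (Homo sapiens), read by fluorescence and calcium flux, with a stated time of 15 min (a lower number here means that less compound is needed, a higher number that more compound is needed for the effect), compound 1 gives 67 nM, whereas compound 2 gives 40000 nM. Going by the values given here, of the two numbers, compound 2 stands highest; its only neighbour is compound 1, whose number is far lower, a gap well beyond the usual scatter. Among the compounds with values here, no single-change step between measured compounds is available, as the two differ in more than one place.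

Compound 3 `COCCN(Cc1cccs1)C(=O)COc1ccc(C)cc1` has not yet been measured. It differs from compound 2 in one place: 2-methoxyethyl in place of cyclohexyl on an amide-type nitrogen. With the ring on the amide-type nitrogen gone, compound 3 resembles compound 1 more closely than compound 2 does. Compound 3 is therefore expected to give a much lower number than compound 2 in this assay, a step of a 100-fold lower number from compound 2 to compound 3 (2.00 log units; beyond the scatter) well beyond the scatter. For compound 3 the estimate is 400 nM, with a range from 60 nM to 4000 nM.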

Compound 3, half-maximal effective concentration: 400 nM
Estimate against measurement, compound 3: no gap at the digits printed, and the stated range covers the measured number.
By their numbers in this assay, from the lowest: compound 1; then compound 3; then compound 2.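

In this assay, putting 2-methoxyethyl in place of cyclohexyl on the amide-type nitrogen gives a 100-fold lower number from compound 2 to compound 3 (2.00 log units; beyond the scatter), so this position alone is now seen to move the number by a large step, which the earlier pair, differing in more than one place, could not show. The change removes a six-membered non-aromatic ring of carbon only and adds an open chain with one hydrogen-bond acceptor, and this single step cannot separate those two differences. No measured evidence gives a reason for the step.

The compounds shown leave open whether a butyl chain, which has a similar open shape but no oxygen, would give a number close to that of compound 3. They also leave open how a chain ending in an amine or a carboxylic acid would fare at this position.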